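From formyl to a hydroxyethylamino methyl arm

The source may report more compounds than this note shows. Statements on the series, on what has been measured and on what is new or still open speak of the compounds shown alone.

Within the data shown here, compound 1 `COc1ccc(/C=C\c2cc(OC)c(OC)c(OC)c2)cc1OCc1ccc(C=O)cc1` stands as the only firm number in this set: in an ADME assay on NCM460 cells (Homo sapiens) for cytotoxicity, read by CCK-8 assay, with a stated time of 48 h (on this read-out lower numbers stand for stronger inhibition and higher numbers for weaker inhibition), compound 1 gives 41000 nM. Compound 2 `COc1ccc(/C=C\c2cc(OC)c(OC)c(OC)c2)cc1OCc1ccc(CN2CCCCC2C(=O)O)cc1` gives in this assay only a limit, > 50000 nM. Among the measured compounds shown here, the one measured step is an at least 1.2-fold higher number from compound 1 to compound 2 (0.08 log units; that floor lies within the scatter), where the limit of > 50000 nM in this assay, at which 1 of the 2 values shown sits, applies. Compound 3 `COc1ccc(/C=C\c2cc(OC)c(OC)c(OC)c2)cc1OCc1ccc(CNCCO)cc1` carries ((2-hydroxyethyl)amino)methyl in place of formyl on an aromatic carbon. Because the step of an at least 1.2-fold higher number from compound 1 to compound 2 (0.08 log units; that floor lies within the scatter) stays within the scatter, a step of a 1.2-fold higher number from compound 1 to compound 3 (0.09 log units; within the scatter) is expected, with the number possibly again reaching only a limit. Compound 3 is estimated at 50000 nM, between 25000 nM and 100000 nM.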

Compound 3, half-maximal inhibitory concentration: 39000 nM
The estimate for compound 3 lay 1.3-fold (0.11 log units) above the measured number; measured number inside the range.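

In this assay, replacing formyl with ((2-hydroxyethyl)amino)methyl on this aromatic carbon gives a 1.1-fold lower number from compound 1 to compound 3 (0.02 log units; within the scatter), so this larger arm leaves the number indistinguishable from that of compound 1. Unlike the carboxylic acid arm, it also gives a firm number, whereas compound 2 stays a limit of the assay: the limit of > 50000 nM in this assay, at which 1 of the 3 values shown sits. The comparison with that limit gives only a floor, an at least 1.2-fold lower number from compound 2 to compound 3 (0.10 log units; that floor lies within the scatter).

On these data alone, what a longer chain on the nitrogen would do at this position remains open, as does a carboxylic acid placed directly on the aromatic carbon.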